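Swapping the aryl group on a spiro-isoxazoline sesquiterpenoid lactone

The source may hold more compounds than are shown below. What is called first, only, known or untested is meant among the compounds shown, and "the series" means these compounds.

Compound 1, `C[C@H]1CC[C@@H]2[C@@H](OC(=O)[C@]23CC(c2ccccc2)=NO3)[C@]2(C)C(=O)C=C[C@@]12O`: 46000 nM
Compound 2, `C[C@H]1CC[C@@H]2[C@@H](OC(=O)[C@]23CC(c2ccc([N+](=O)[O-])cc2)=NO3)[C@]2(C)C(=O)C=C[C@@]12O`: 12000 nM

For the measured compounds named here, in a functional assay on PC-3 cells (Homo sapiens) for cytotoxicity, read by sulforhodamine B assay, with a stated time of 48 h (a higher number here means a weaker inhibitor, a lower number a stronger inhibitor), compound 2 gives 12000 nM, the lowest of the two numbers so far. Going by the values given here, its nearest neighbour is compound 1, and the only measured step, a 3.8-fold lower number from compound 1 to compound 2 (0.58 log units; beyond the scatter), separates them. Compound 3, `COc1cc(C2=NO[C@]3(C2)C(=O)O[C@@H]2[C@H]3CC[C@H](C)[C@]3(O)C=CC(=O)[C@@]23C)ccc1O`, is not yet measured. It differs from compound 2 in one place: 4-hydroxy-3-methoxyphenyl in place of 4-nitrophenyl on a carbon with a double bond to nitrogen. Among the compounds with values here, no measured step covers this change; the single step that exists concerns nitro in place of hydrogen on an aromatic carbon, and here the 4-nitrophenyl leaves while the 4-hydroxy-3-methoxyphenyl enters. With the nitro-bearing aryl gone, compound 3 is expected to move back toward the number of compound 1, a step of a 2.5-fold higher number from compound 2 to compound 3 (0.40 log units; beyond the scatter), with wide uncertainty. Compound 3 is thus estimated at 30000 nM, within a range of 10000 nM to 90000 nM.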

Compound 3, half-maximal inhibitory concentration: 16000 nM
For compound 3 the middle estimate is 1.9-fold (0.27 log units) above the measured one; low and high end bracket the measured number.
By their numbers in this assay, from the lowest: compounds 2 and 3 (each within the scatter of the next); then compound 1.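

In this assay the step of a 1.3-fold higher number from compound 2 to compound 3 (0.12 log units; within the scatter) lies within the scatter, so on this carbon with a double bond to nitrogen, 4-hydroxy-3-methoxyphenyl and 4-nitrophenyl cannot be told apart. Set against the unsubstituted phenyl, the same group gives a 2.9-fold lower number from compound 1 to compound 3 (0.46 log units; beyond the scatter) as a modest step beyond the scatter, so the gain over phenyl is no longer seen with the nitro-bearing aryl alone. No supporting data bear on why these two different aryl groups read alike.

The compounds shown leave open whether the hydroxy or the methoxy of the entering group accounts for its step from phenyl. They also leave open how an amine or a carboxylic acid on the aryl ring, or a longer alkyl chain in place of the ring, would read here.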